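The compounds below may be only part of what the source reports. "The series", "measured", "known", "first", "only" and "open" are said of these compounds alone.

Three compounds sharing one core have been examined in an ADME assay on microsomes from liver (Rattus norvegicus) for metabolic stability; on this read-out higher numbers stand for a longer-lived compound and lower numbers for a shorter-lived compound. Compound 1 `CC(C)C(c1nnc[nH]1)c1ccc(-c2ccc3cccc(F)c3c2)[nH]c1=O` gives 0.552 h. Compound 2 `CC(C)C(c1ncco1)c1ccc(-c2ccc3cccc(F)c3c2)[nH]c1=O` gives 0.0983 h, and compound 3 `CC(C)C(c1cnc(N)s1)c1ccc(-c2ccc3cccc(F)c3c2)[nH]c1=O` gives 0.0983 h, so compound 3 sits level with compound 2 at the lowest of the three numbers, while the step of a 5.6-fold lower number from compound 1 to compound 3 (0.75 log units; beyond the scatter) shows how far compound 1 lies above it. Compound 4 `CC(C)C(Cc1noc(=O)[nH]1)c1ccc(-c2ccc3cccc(F)c3c2)[nH]c1=O` differs from compound 3 in one place: a group of 7 heavy atoms (3 carbon, 2 nitrogen, 2 oxygen; one five-membered aromatic ring with 3 hetero atoms) in place of a group of 6 heavy atoms (3 carbon, 2 nitrogen, 1 sulfur; one five-membered aromatic ring with 2 hetero atoms), on a saturated chain carbon bound to an aromatic carbon and a saturated chain carbon. The step of no change at the digits printed from compound 2 to compound 3 (within the scatter) shows that swapping one five-membered ring for another did nothing beyond the scatter, whereas a 5.6-fold lower number from compound 1 to compound 3 (0.75 log units; beyond the scatter) shows such a swap can shift the number modestly. A modest rise is therefore the expected outcome, a 2.0-fold higher number from compound 3 to compound 4 (0.31 log units; beyond the scatter). Compound 4 is accordingly estimated at 0.2 h, with a range from 0.08 h to 0.6 h.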

Compound 4, half-life: > 3 h
Compound 4: only a limit was reported; the forecaster's own chance of this, stated with the estimate: 5%; at least 15-fold (1.17 log units) between middle value and limit.
By their numbers in this assay, from the lowest: compounds 2 and 3 (each within the scatter of the next); then compound 1. At a limit, above all of these: compound 4.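

In this assay, the group on this saturated chain carbon can matter far more than the earlier swaps suggested, with an at least 30-fold higher number from compound 3 to compound 4 (1.48 log units; beyond the scatter) and an at least 30-fold higher number from compound 2 to compound 4 (1.48 log units; beyond the scatter). The count of ring hetero atoms alone does not settle it, as compound 1 and compound 4 both carry 3 and still show an at least 5.4-fold higher number from compound 1 to compound 4 (0.73 log units; beyond the scatter). The reading for compound 4 is a limit of the assay, not a number: the limit of > 3 h in this assay, at which 1 of the 4 values shown sits.

From the compounds shown here alone, how far compound 4 lies past that limit stays open. So does whether a carboxylic acid or an amine at this place would give a similar half-life.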